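A Cycloalkyl Amine Gives Way to a Fluorinated Aryl Amine

The source may report more compounds than this note shows. Statements on the series, on what has been measured and on what is new or still open speak of the compounds shown alone.

Compound 1 `O=C1C(NC2CC2)=CC(=O)c2c1nc1n2[C@H]2OC[C@@H](O)[C@H]2OC1`: > 16000 nM
Compound 2 `O=C1C=C(NC2CCCC2)C(=O)c2c1nc1n2[C@H]2OC[C@@H](O)[C@H]2OC1`: > 16000 nM
Compound 3 `COc1ccc(NC2=CC(=O)c3nc4n(c3C2=O)[C@H]2OC[C@@H](O)[C@H]2OC4)cc1`: 4780 nM

In a functional assay on HeLa cells (Homo sapiens) for inhibition, read by sulforhodamine B assay (on this read-out lower numbers stand for stronger inhibition and higher numbers for weaker inhibition), compound 1 gives only a limit of the assay, not a number. Compound 2 likewise sits at a limit. Compound 3 gives a measured number. For the measured compounds named here, compound 1 thus stands at the limit of > 16000 nM in this assay, at which 2 of the 3 values shown sit, with the one numerical value in this set belonging to compound 3.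

Compound 4 `O=C1C(Nc2cccc(F)c2)=CC(=O)c2c1nc1n2[C@H]2OC[C@@H](O)[C@H]2OC1` is not yet measured. It differs from compound 1 by 3-fluorophenyl in place of cyclopropyl on an amine nitrogen, the cyclopropyl leaving and the 3-fluorophenyl entering on an amine nitrogen. Going by the values given here, the one measured step that bears on such an exchange of a ring on that nitrogen is an at least 3.3-fold lower number from compound 2 to compound 3 (0.52 log units; beyond the scatter), in which an aryl ring also replaced a cycloalkyl ring. A lowering step beyond the scatter is therefore expected in this assay, and compound 4 is expected to show an at least 3.2-fold lower number from compound 1 to compound 4 (0.50 log units; beyond the scatter). Compound 4 is estimated at 5000 nM, between 2000 nM and 16000 nM.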

Compound 4, half-maximal inhibitory concentration: > 8000 nM
Compound 4: only a limit was reported (the forecaster's own chance of this, stated with the estimate: 25%); middle value at least 1.6-fold (0.20 log units) away from the limit.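

Compound 4 gives only a limit, > 8000 nM. Compound 1 also gives only a limit, > 16000 nM, so no step can be read between compound 1 and compound 4. The compounds shown leave open whether 3-fluorophenyl in place of cyclopropyl changes inhibition at all.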